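Aryl swap at the pyrimidine carbon of the shared core

The source may report more compounds than this note shows. Statements on the series, on what has been measured and on what is new or still open speak of the compounds shown alone.

Among the compounds with values here, compound 2 `Nc1nc(-c2cnco2)nc2sc(Cc3ccccc3)cc12` gives 106 nM in a functional assay on CHO-K1 cells for antagonist activity at adenosine receptor A1 (Homo sapiens), read by a beta-galactosidase reporter and cAMP accumulation, with stated times of 15 min and 6 h (a higher number here means a weaker inhibitor, a lower number a stronger inhibitor), the lowest of the two numbers so far; compound 1 `Nc1nc(C2CCCO2)nc2sc(Cc3ccccc3)cc12` gives 2950 nM. Within the data shown here, the one measured step, a 28-fold lower number from compound 1 to compound 2 (1.44 log units; beyond the scatter), is large. Compound 3 `COc1cccc(-c2nc(N)c3cc(Cc4ccccc4)sc3n2)c1` carries 3-methoxyphenyl in place of 1,3-oxazol-5-yl on an aromatic carbon on an aromatic carbon of the six-membered aromatic ring with 2 nitrogen. Among the measured compounds shown here, no measured step exchanges one aromatic ring for another here, so that step does not bear directly on this change; an aromatic group stays in place. For compound 3 the expected step is a 1.3-fold lower number from compound 2 to compound 3 (0.12 log units; within the scatter), within the scatter. Compound 3 is estimated at 80 nM, range 20 nM to 400 nM.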

Compound 3, inhibition constant: 266 nM
Beside the measured number, compound 3's estimate is 3.3-fold (0.52 log units) below it, within the range that was stated.
By their numbers in this assay, from the lowest: compound 2; then compound 3; then compound 1.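

In this assay, the gain over oxolan-2-yl does not depend on the five-membered ring with 2 hetero atoms: 3-methoxyphenyl, a six-membered aromatic ring of carbon only, also gives a large step (an 11-fold lower number from compound 1 to compound 3 (1.04 log units; beyond the scatter)). The two aromatic groups are still distinguishable, with 1,3-oxazol-5-yl favoured by a modest step (a 2.5-fold higher number from compound 2 to compound 3 (0.40 log units; beyond the scatter)). No measurement here gives a reason for either step.

Whether the methoxy group contributes remains open, since unsubstituted phenyl is not among the compounds shown. Going by these compounds, how a pyridyl ring or an open alkyl chain would read at this carbon also remains open.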